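The source may hold more compounds than are shown below. What is called first, only, known or untested is meant among the compounds shown, and "the series" means these compounds.

Measured compounds: compound 1 `O=C(Nc1ccc(C(F)(F)F)cc1)C1c2ccccc2CCN1C(=O)c1ccc(Cl)cc1`, compound 2 `COc1ccc(NC(=O)C2c3ccccc3CCN2C(=O)c2ccc(Cl)cc2)cc1`.

In a functional assay on PC-3 cells (Homo sapiens) for inhibition, read by sulforhodamine B assay, with a stated time of 48 h (a lower number here means a stronger inhibitor of growth, a higher number a weaker inhibitor of growth), compound 1 gives 4490 nM, and compound 2 gives 3480 nM. Compound 1 holds the highest of the two numbers, and the nearest, compound 2, is separated from it by a 1.3-fold lower number from compound 1 to compound 2 (0.11 log units; within the scatter), a step that involves methoxy in place of trifluoromethyl on an aromatic carbon.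

Compound 3 `O=C(Nc1ccc(C(F)(F)F)cc1)C1NCCc2ccccc21` has not been measured. It differs from compound 1 by hydrogen in place of (4-chlorophenyl)carbonyl on an amine nitrogen in a ring. Going by the values given here, no measured step bears on this change: the single step known alters the aromatic substituent on the amide side and leaves the ring nitrogen untouched, so it gives no guide to what the loss of the (4-chlorophenyl)carbonyl group will do. With nine heavy atoms leaving and only hydrogen entering, the change is large, and a weakening of growth inhibition beyond the scatter is expected for compound 3, corresponding to a 3.3-fold higher number from compound 1 to compound 3 (0.52 log units; beyond the scatter). Compound 3 is estimated to give 15000 nM in this assay, within a range from 3500 nM to 60000 nM.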

Compound 3, concentration for 50% growth inhibition: 6590 nM
Compound 3: the middle estimate sits 2.3-fold (0.36 log units) above what was measured; the measured number falls inside the stated range.
By their numbers in this assay, from the lowest: compounds 2, 1 and 3 (each within the scatter of the next).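

In this assay, going by these compounds alone, the exchange of the (4-chlorophenyl)carbonyl group for hydrogen on the amine nitrogen in the ring gives a 1.5-fold higher number from compound 1 to compound 3 (0.17 log units; within the scatter), the first reading at this position. The whole group, with its aromatic ring and its carbonyl, can therefore leave this pair without a change in the number beyond the scatter, so at this level of growth inhibition compound 1 shows no measurable gain from it over compound 3. Nothing among the data given explains this result.

The compounds shown leave open whether a small acetyl group, a methyl group or a benzyl group on the same nitrogen would read alike. They also leave open whether a methoxy group in place of trifluoromethyl on the aromatic carbon would give a similar reading with hydrogen on the ring nitrogen.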